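Amide for fluoro on the fused ring: compound 4

The compounds below may be only part of what the source reports. "The series", "measured", "known", "first", "only" and "open" are said of these compounds alone.

Compound 1 `CC[C@@H]1C(=O)N(C)c2cnc(-n3ccc4cc(F)ccc43)nc2N1C1CCCC1` carries a fluoro on the fused two-ring system of the shared core. In a functional assay on A549 cells (Homo sapiens) for antiproliferative activity, read by CCK-8 assay, with a stated time of 72 h (a higher number here means a weaker inhibitor of growth, a lower number a stronger inhibitor of growth), compound 1 is reported as "not active" (no number reported), so no number stands for it and it cannot be placed on the scale of the others. Two related compounds do give numbers. Compound 2 `CCC1C(=O)N(C)c2cnc(-n3ccc4cc(C(N)=O)ccc43)nc2N1c1ccn(C)n1` gives 39500 nM in this assay. Compound 3 `CCCNS(=O)(=O)c1ccc(Nc2ncc3c(n2)N(c2ccn(C)n2)C(CC)C(=O)N3C)cc1` gives 15000 nM in this assay. Among the measured compounds shown here, both sit at the weak end of the scale; they differ from each other in more than one place and no step between them is computed.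

Compound 4 `CC[C@@H]1C(=O)N(C)c2cnc(-n3ccc4cc(C(=O)NCC(C)C)ccc43)nc2N1C1CCCC1` is compound 1 with a single change: isobutylcarbamoyl in place of fluoro on an aromatic carbon. Compound 2, at 39500 nM, also carries a carbamoyl group and reaches a measurable value, whereas compound 1 with fluoro does not. On that basis the move from compound 1 to compound 4 is expected to run toward stronger inhibition of growth, but the size of the step cannot be stated, since compound 1 has no number to measure it from. For compound 4 the estimate in this assay is 12000 nM, between 3000 nM and 50000 nM, with a real chance that only a limit is reported.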

Compound 4, concentration for 50% growth inhibition: 1730 nM
The estimate for compound 4 lay 6.9-fold (0.84 log units) above the measured number, and the stated range ends above it.
By their numbers in this assay, from the lowest: compound 4; then compound 3; then compound 2.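

Among the compounds shown here, compound 1 has no number in this assay, so no step from it to compound 4 can be read. The compounds shown leave open how much isobutylcarbamoyl in place of fluoro contributes on its own, as no pair with two numbers differs in that one place. No supporting data bear on this result.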